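A few compounds are considered here, and "the series" means these few. Any claim that something is new, unique, unknown or untested is made for them only; others in the source may bear on it.

Compound 2 `COc1ccc(Cn2cc(CNC(=O)c3cn(-c4ccccc4)nc3-c3ccc(F)cc3)nn2)cc1OC` carries a phenyl on one nitrogen of its shared core, a 4-fluorophenyl on the neighbouring carbon, and an amide arm ending in a second ring that bears a 3,4-dimethoxyphenyl on a saturated chain carbon bound to an aromatic nitrogen. In a functional assay on HeLa cells (Homo sapiens) for antiproliferative activity, read by sulforhodamine B assay, with a stated time of 48 h (on this read-out lower numbers stand for stronger inhibition of growth and higher numbers for weaker inhibition of growth), compound 2 gives 200 nM, the lowest of the three numbers measured here. Compound 1 `O=C(NCc1cn(Cc2ccc(F)cc2)nn1)c1cn(-c2ccccc2)nc1-c1ccc(F)cc1`, with 4-fluorophenyl at that chain carbon, gives 1200 nM, and compound 3 `COc1cc(Cn2cc(CNC(=O)c3cn(-c4ccccc4)nc3-c3ccc(F)cc3)nn2)cc(OC)c1OC`, with 3,4,5-trimethoxyphenyl there, gives 2100 nM. The steps between them are a 6.0-fold lower number from compound 1 to compound 2 (0.78 log units; beyond the scatter) and an 11-fold higher number from compound 2 to compound 3 (1.02 log units; beyond the scatter), while a 1.8-fold higher number from compound 1 to compound 3 (0.24 log units; within the scatter).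

Compound 4 `COc1ccc(-c2nn(-c3ccccc3)cc2C(=O)NCc2cn(Cc3ccc(OC)c(OC)c3)nn2)cc1` differs from compound 2 at the other end of the molecule: methoxy in place of fluoro on an aromatic carbon. Among the compounds with values here, none of the measured steps touches this ring, so they give no direct guide, only a sense of how far the numbers move from one compound to the next. Compound 4 is therefore estimated near compound 2, and the expected step is a 1.5-fold higher number from compound 2 to compound 4 (0.18 log units; within the scatter). Compound 4 is expected to give about 300 nM, within a range from 100 nM to 1200 nM.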

Compound 4, concentration for 50% growth inhibition: 800 nM
Compound 4: middle estimate off by 2.7-fold (0.43 log units), on the low side; the range from low to high includes it.
By their numbers in this assay, from the lowest: compound 2; then compounds 4, 1 and 3 (each within the scatter of the next, the first and the last beyond it).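

The earlier compounds shown here varied only the group on the saturated chain carbon, so they said nothing about the 4-fluorophenyl on the shared core. Replacing it with 4-methoxyphenyl gives a 4.0-fold higher number from compound 2 to compound 4 (0.60 log units; beyond the scatter), which shows that this end of the molecule also affects growth inhibition: with the arm of compound 2 held fixed, fluoro is favoured over methoxy at this aromatic carbon, para to a large group. No measurement shown here explains why the number rises with this change.

As far as these compounds go, this is a single change made on a single arm, so it remains open whether methoxy would raise the number in the same way with 4-fluorophenyl or 3,4,5-trimethoxyphenyl on the chain carbon. From the compounds shown here alone, how a hydroxyl or an amine at this aromatic carbon would compare with fluoro and methoxy also remains open.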